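A few compounds are considered here, and "the series" means these few. Any claim that something is new, unique, unknown or untested is made for them only; others in the source may bear on it.

Two compounds built on one shared core have so far been examined in a functional assay on MCF7 cells (Homo sapiens) for cytotoxicity; on this read-out higher numbers stand for an effect only at larger amounts of compound and lower numbers for an effect already at smaller amounts. Compound 1 `CCCCCCn1c(Cc2cc(OC)c(OC)c(OC)c2)nc2c(N)nc(F)nc21` gives 112000000 nM there, and compound 2 `C=CCCCn1c(Cc2cc(OC)c(OC)c(OC)c2)nc2c(N)nc(F)nc21` gives 55600000 nM in this assay. Among the compounds with values here, the single measured step, a 2.0-fold lower number from compound 1 to compound 2 (0.30 log units; within the scatter), is too small to carry any message of its own. Among the two numbers compound 2 holds the lower one, yet its only neighbour, compound 1, stands so near that no order can be read from the pair.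

Compound 3 `CC#CCCn1c(Cc2cc(OC)c(OC)c(OC)c2)nc2c(N)nc(F)nc21` differs from compound 2 by prop-1-yn-1-yl in place of allyl on a saturated chain carbon, two bonds along the chain from an aromatic nitrogen. Within the data shown here, no measured step covers a triple bond entering this chain, so the expectation rests on the one step between compound 1 and compound 2, in which reshaping the same stretch of chain left the read-out within the scatter. On that basis no shift beyond the scatter is expected for compound 3, estimated as a 1.1-fold higher number from compound 2 to compound 3 (0.03 log units; within the scatter). Compound 3 is therefore expected to give about 60000000 nM in this assay, with a range from 20000000 nM to 200000000 nM.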

Compound 3, half-maximal effective concentration: 95500000 nM
Compound 3: middle estimate off by 1.6-fold (0.20 log units), on the low side, within the range that was stated.
By their numbers in this assay, from the lowest: compounds 2, 3 and 1 (each within the scatter of the next).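

With the triple bond now in the chain, the step to prop-1-yn-1-yl from allyl in this assay reads a 1.7-fold higher number from compound 2 to compound 3 (0.23 log units; within the scatter) and the step to it from butyl reads a 1.2-fold lower number from compound 1 to compound 3 (0.07 log units; within the scatter), so neither step leaves the scatter. On a saturated chain carbon, two bonds along the chain from an aromatic nitrogen, compounds 1, 2 and 3 therefore cannot be told apart in this read-out, whether the chain is saturated or carries a double or a triple bond, and compound 3 adds the triple bond to the chain forms that the first pair could not separate. No measured information is available that could explain these numbers or tie them to any feature of the chain.

The compounds shown leave open whether a chain ending in an amine, a hydroxyl or a carboxylic acid, or a much shorter chain such as ethyl, would move the number beyond the scatter, since all three chains here are built of carbon and hydrogen alone. They also leave open whether replacing the fluorine or the methoxy groups on the shared core would do so.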